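This account rests on a few compounds, and the source may have more. Where it says the series, first, only, none or still open, it means among the compounds named here.

Going by the values given here, compound 2 `COCN(N)c1nnc(-c2ccccc2Cl)s1` is the one compound in this set with a numerical result: in a functional assay on the whole organism with Mus musculus as the target, with a stated time of 1 h (a lower number here means that less compound is needed, a higher number that more compound is needed for the effect), compound 2 gives 60 mg/kg. Compound 1 `CC(C)N(N)c1nnc(-c2ccccc2Cl)s1` gives only a limit in this assay, > 100 mg/kg, which means no number could be fixed for it. Among the compounds with values here, the single measured step is therefore an at least 1.6-fold lower number from compound 1 to compound 2 (0.22 log units; that floor lies within the scatter), and it is only a floor that sits inside the usual scatter, so it shows no real change in this assay; it is marked by the limit of > 100 mg/kg in this assay, at which 1 of the 2 values shown sits.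

Compound 3 `CNN(C)c1nnc(-c2ccccc2Cl)s1` has not yet been measured in this assay. It differs from compound 2 by methyl(methylamino)amino in place of amino(methoxymethyl)amino on an aromatic carbon. Within the data shown here, this change touches the same nitrogen-bearing group on the shared core as the measured step, yet the group that enters is different from both earlier ones, so the one measured step gives little guidance and no direction for this assay can be expected with confidence. Compound 3 is expected to sit close to compound 2, so the step of no change at the digits printed from compound 2 to compound 3 (within the scatter) is estimated to stay within the scatter. The estimate for compound 3 in this assay is 60 mg/kg, with a range from 25 mg/kg to 150 mg/kg.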

Compound 3, dose for half-maximal effect: 25 mg/kg
Compound 3: the middle estimate sits 2.4-fold (0.38 log units) above what was measured; low and high end bracket the measured number.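

In this assay, going by these compounds alone, replacing amino(methoxymethyl)amino with methyl(methylamino)amino on this aromatic carbon gives a 2.4-fold lower number from compound 2 to compound 3 (0.38 log units; beyond the scatter), so this is the first change here that clearly exceeds the usual scatter. The comparison with the isopropyl-bearing group gives an at least 4.0-fold lower number from compound 1 to compound 3 (0.60 log units; beyond the scatter), which also exceeds the scatter and shows that the dose needed for the effect depends on the group at this position, a point the earlier step could not establish. The true size of that second step remains unknown, as the value for compound 1 is a limit and the step is only a floor: the limit of > 100 mg/kg in this assay, at which 1 of the 3 values shown sits.

The entering and leaving groups differ on both nitrogens, so the compounds shown cannot separate the effect of the methyl on one nitrogen from that of the methyl on the other. Going by these compounds, it also remains open whether a dimethylamino group, an ethyl chain on either nitrogen, or a cyclic amine such as morpholine at this position would lower the required dose further or raise it.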